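This account rests on a few compounds, and the source may have more. Where it says the series, first, only, none or still open, it means among the compounds named here.

Values in a functional assay on A-375 cells (Homo sapiens) for cytotoxicity, read by MTT assay, with a stated time of 72 h; on this read-out higher numbers stand for weaker inhibition and lower numbers for stronger inhibition:
compound 1 `CN(C)CCCCCn1c2c(c3ccccc31)C(=O)c1c[n+]([O-])c3ccccc3c1C2=O`: 560 nM
compound 2 `O=C1c2c[n+]([O-])c3ccccc3c2C(=O)c2c1c1ccccc1n2CCCCN1CCNCC1`: 460 nM
compound 3 `CCCCN1CCN(CCCCn2c3c(c4ccccc42)C(=O)c2c[n+]([O-])c4ccccc4c2C3=O)CC1`: 2150 nM

Compound 3 has the highest number of the three and so the weakest inhibition in this assay, with its steps to both others beyond the scatter. Compound 4 `CN(C)CCCCn1c2c(c3ccccc31)C(=O)c1c[n+]([O-])c3ccccc3c1C2=O` differs from it by one change: dimethylamino in place of 4-butylpiperazin-1-yl on a saturated chain carbon, four bonds along the chain from an aromatic nitrogen. In words, this is dimethylamino in place of 4-butylpiperazin-1-yl on a saturated chain carbon, four bonds along the chain from an aromatic nitrogen.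

Going by the values given here, two measured steps bear on this most directly, and both are modest. The first, a 3.8-fold higher number from compound 1 to compound 3 (0.58 log units; beyond the scatter), came with 4-butylpiperazin-1-yl in place of (dimethylamino)methyl, which is the closest measured counterpart, run in the opposite direction. The second, a 4.7-fold higher number from compound 2 to compound 3 (0.67 log units; beyond the scatter), came with butyl in place of hydrogen on an amine nitrogen in a ring. By contrast, a 1.2-fold lower number from compound 1 to compound 2 (0.09 log units; within the scatter) shows no separation between those two compounds.

On the size of a 3.8-fold higher number from compound 1 to compound 3 (0.58 log units; beyond the scatter), a modest move to a lower number is expected, back towards the level of compound 1 and compound 2. Among the compounds with values here, no measured compound carries this exact side chain, so the range is kept wide. The expected step is a 4.1-fold lower number from compound 3 to compound 4 (0.62 log units; beyond the scatter). Compound 4 is estimated at 520 nM, with an expected range of 220 nM to 1200 nM.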

Compound 4, half-maximal inhibitory concentration: 470 nM
For compound 4 the middle estimate is 1.1-fold (0.04 log units) above the measured one; low and high end bracket the measured number.
By their numbers in this assay, from the lowest: compounds 2, 4 and 1 (each within the scatter of the next); then compound 3.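

In this assay the exchange of 4-butylpiperazin-1-yl for dimethylamino on this saturated chain carbon (a 4.6-fold lower number from compound 3 to compound 4 (0.66 log units; beyond the scatter)) shows that the large butylated ring is not needed for the level reached by compound 2, since a small open-chain amine with no ring does as well. Dimethylamino is not separated from piperazin-1-yl (a 1.0-fold higher number from compound 2 to compound 4 (0.01 log units; within the scatter)) or from (dimethylamino)methyl (a 1.2-fold lower number from compound 1 to compound 4 (0.08 log units; within the scatter)), so among these four compounds only compound 3 stands apart, and the other three side chains cannot be ranked on these numbers. Nothing given here accounts for this difference or for the absence of one among the other three.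

The compounds shown leave open whether the step to compound 3 belongs to the butyl group itself or would also appear with a methyl or an acetyl on the same ring nitrogen. They also leave open how a morpholine ring, a primary amine or a shorter chain carrying dimethylamino would compare at this place.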